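Propyl for methyl on one ester of compound 2

The source may hold more compounds than are shown below. What is called first, only, known or untested is meant among the compounds shown, and "the series" means these compounds.

Of the compounds shown here, two of a shared core have been tested in an assay on isolated protein (strain albino) for antagonist activity at Voltage-dependent L-type calcium channel subunit alpha-1C (Cavia porcellus); on this read-out higher numbers stand for weaker inhibition and lower numbers for stronger inhibition. Compound 1, `COCCOC(=O)C1=C(C)NC(C)=C(C(=O)OCCOC)C1c1cnc(SC)n1Nc1ccccc1`, carries the larger alkoxy group on both esters; in this assay compound 1 gives 17.9 nM. Compound 2, `COC(=O)C1=C(C)NC(C)=C(C(=O)OC)C1c1cnc(SC)n1Nc1ccccc1`, carries the smaller group on both esters; in this assay compound 2 gives 3.54 nM, the lower of the two numbers, and the gap to compound 1 lies beyond the scatter.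

Compound 3, `CCCOC(=O)C1=C(C)NC(C)=C(C(=O)OC)C1c1cnc(SC)n1Nc1ccccc1`, has not been measured. It differs from compound 2 in one place: ethyl in place of hydrogen on a saturated chain carbon bound to an oxygen next to a carbonyl group. Within the data shown here, the two measured compounds differ in more than one place, so no single step between them can be read, and what compound 1 shows is only that the compound with both larger esters gives the higher number.

On that basis, the step from compound 2 to compound 3 is expected to be small, toward a somewhat higher number, and likely within the scatter: a 1.6-fold higher number from compound 2 to compound 3 (0.19 log units; within the scatter). Compound 3 is therefore estimated at 5.5 nM, within a range of 1.8 nM to 17 nM.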

Compound 3, half-maximal inhibitory concentration: 2.4 nM
For compound 3 the middle estimate is 2.3-fold (0.36 log units) above the measured one; measured number inside the range.
By their numbers in this assay, from the lowest: compounds 3 and 2 (each within the scatter of the next); then compound 1.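

In this assay, among these compounds, exchanging methoxycarbonyl for propoxycarbonyl on one ester gives a 1.5-fold lower number from compound 2 to compound 3 (0.17 log units; within the scatter), and this is the first single change at an ester that can be read on its own. It shows that, on this one ester of the shared core, the saturated chain carbon bound to an oxygen next to a carbonyl group can carry ethyl in place of hydrogen without the number moving beyond the scatter. No data are available that bear on this result.

As far as these compounds go, compound 1 differs from compound 2 and from compound 3 in more than one place, so those steps cannot be read, and what its larger alkoxy groups contribute on each ester separately stays open. From the compounds shown here alone, it is also open whether propoxycarbonyl on both esters, a longer chain such as butoxycarbonyl, or a carboxylic acid at this ester would keep the number in the same range in this assay.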